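Swapping an amide for an amine: cytotoxicity expected to stay low

A few compounds are considered here, and "the series" means these few. Any claim that something is new, unique, unknown or untested is made for them only; others in the source may bear on it.

Measured so far in a toxicity assay on NIH3T3 cells (Mus musculus) for cytotoxicity, read by resazurin assay; on this read-out lower numbers stand for an effect already at smaller amounts and higher numbers for an effect only at larger amounts of compound:
- compound 1 `Nc1cc(-c2ccccc2)ccc1Cn1cncc1CNc1ccc(-c2cncs2)c(-c2ccccc2)c1`: > 1000 nM
- compound 2 `O=C(c1ccc(NCc2cncn2Cc2ccc(-c3ccccc3)cc2)cc1-c1ccccc1)N1CCCCC1`: > 1000 nM
- compound 3 `Cc1cccc(-c2cc(NCc3cncn3Cc3ccc(-c4ccccc4)cc3)ccc2-c2nc3ccccc3s2)c1C`: > 1000 nM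

All three of these values are limits of the assay rather than numbers. Compound 2 therefore stands at the limit, as described by the limit of > 1000 nM in this assay, at which 3 of the 3 values shown sit, so nothing distinguishes it from the other two.

The next compound, compound 4 `c1ccc(-c2ccc(Cn3cncc3CNc3ccc(N4CCCCC4)c(-c4ccccc4)c3)cc2)cc1`, differs from compound 2 in one place: piperidin-1-yl in place of (piperidin-1-yl)carbonyl on an aromatic carbon. The rest of the shared core is kept.

Among the measured compounds shown here, no change between measured compounds in this set moves the read-out off the limit, so there is no measured step to size this change against. The expected step in this assay from compound 2 to compound 4 is therefore none beyond the scatter, a step that the limit leaves unreadable from compound 2 to compound 4, with the likeliest outcome that compound 4 also comes back as a limit. The estimate for compound 4 in this assay is 2000 nM, with a range from 700 nM to 10000 nM.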

Compound 4, half-maximal effective concentration: > 1000 nM
Compound 4 was reported as a limit; the forecaster's own chance of this, stated with the estimate: 70%; the middle value does not contradict the limit.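

In this assay, compound 2 and compound 4 both come back as limits rather than numbers, so no step can be read between them: the limit of > 1000 nM in this assay, at which 4 of the 4 values shown sit.

The compounds shown leave open at what concentration any of them would harm these cells, and whether replacing (piperidin-1-yl)carbonyl with piperidin-1-yl changes that concentration.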